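The source may hold more compounds than are shown below. What is called first, only, known or untested is meant among the compounds shown, and "the series" means these compounds.

In a functional assay on T47D cells (Homo sapiens) for cytotoxicity, read by MTT assay, with a stated time of 72 h (on this read-out higher numbers stand for weaker inhibition of growth and lower numbers for stronger inhibition of growth), compound 1, `COc1cc(/C=C/S(=O)(=O)Cc2ccc(OC)c([N+](=O)[O-])c2)cc(OC)c1`, gives only a limit of the assay, > 30000 nM, and not a number. Compound 1 thus sits at the limit of > 30000 nM in this assay, at which 2 of the 3 values shown sit. Compound 3, `COc1ccc(OC)c(NC(=O)CS(=O)(=O)Cc2ccc(OC)c([N+](=O)[O-])c2)c1`, also gives a limit in this assay, > 30000 nM. Compound 2, `COc1ccc(CS(=O)(=O)/C=C/c2ccc(OC)c(OC)c2OC)cc1N`, gives a number in this assay, 5900 nM. Compound 4, `COc1cc(/C=C/S(=O)(=O)Cc2ccc(OC)c(N)c2)cc(OC)c1`, has not yet been measured; it differs from compound 1 by amino in place of nitro on an aromatic carbon. Among the measured compounds shown here, compound 2 also carries an amino group where a nitro group could stand, but the rest of its structure differs from compound 1, so its value shows only that such an amino compound can reach a number in this assay. The expected step from compound 1 to compound 4 in this assay is an at least 3.3-fold lower number from compound 1 to compound 4 (0.52 log units; beyond the scatter), towards stronger inhibition of growth. Compound 4 is therefore estimated at about 9000 nM, within 2000 nM to 30000 nM.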

Compound 4, concentration for 50% growth inhibition: 530 nM
The estimate for compound 4 lay 17-fold (1.23 log units) above the measured number; measured number below the stated range.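

At this position, on an aromatic carbon ortho to a methoxy group, amino in place of nitro is now seen on its own, with the rest of the molecule unchanged: in this assay the change brings an at least 56-fold lower number from compound 1 to compound 4 (1.75 log units; beyond the scatter). Compound 2 also carries an amino group, but on a different core, so it could not show this. The true size of the step stays unknown, as compound 1 gives only a limit: the limit of > 30000 nM in this assay, at which 2 of the 4 values shown sit.

On these data alone, whether another group here, such as hydroxyl or a methylamino group, would do as well as amino remains open. So does whether amino in place of nitro gives a similar step on other cores.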